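From compound 3 to compound 4: an expected drop

A few compounds are considered here, and "the series" means these few. Any claim that something is new, unique, unknown or untested is made for them only; others in the source may bear on it.

Compound 1 `O=C(NCC1(c2nc(-c3ccccc3)cs2)CCOCC1)c1ccc(-n2cncn2)cc1`: 191000 nM
Compound 2 `O=C(NCC1(c2nc(-c3ccccc3)cs2)CCOCC1)c1ccc(Nc2nc3ccccc3s2)cc1`: 4000 nM
Compound 3 `O=C(NCC1(c2nc(-c3ccccc3)cs2)CCOCC1)c1ccc(CN2CCCCC2)cc1`: >= 396000 nM (a limit)

In a physicochemical assay for solubility, read by chemiluminescence, in phosphate buffer, measured as kinetic solubility, at pH 7.4 (a higher number here means a more soluble compound, a lower number a less soluble compound), compound 3 has only a limit, >= 396000 nM, and no number. Compound 4 `O=C(NCC1(c2nc(-c3ccccc3)cs2)CCOCC1)c1ccc(Nc2ccccn2)cc1` carries (pyridin-2-yl)amino in place of (piperidin-1-yl)methyl on an aromatic carbon. The closest measured change is an at least 99-fold higher number from compound 2 to compound 3 (1.99 log units; beyond the scatter), which is large and also swaps an amino-linked group for (piperidin-1-yl)methyl. Also large is a 48-fold lower number from compound 1 to compound 2 (1.68 log units; beyond the scatter), whereas an at least 2.0-fold higher number from compound 1 to compound 3 (0.31 log units; beyond the scatter) is modest. A large move to a lower number in this assay is therefore expected, and the expected step is an at least 13-fold lower number from compound 3 to compound 4 (1.12 log units; beyond the scatter). For compound 4 the estimate is 30000 nM, with an expected range of 8000 nM to 120000 nM.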

Compound 4, solubility: 12000 nM
The estimate for compound 4 lay 2.5-fold (0.40 log units) above the measured number; the range from low to high includes it.
By their numbers in this assay, from the lowest: compound 2; then compound 4; then compound 1. At a limit, above all of these: compound 3.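

In this assay, keeping the amino link on this aromatic carbon and exchanging the group on its nitrogen gives only a 3.0-fold higher number from compound 2 to compound 4 (0.48 log units; beyond the scatter), a smaller move than the other changes at this place. Both amino-linked compounds sit low in the set, with a 16-fold lower number from compound 1 to compound 4 (1.20 log units; beyond the scatter) and an at least 33-fold lower number from compound 3 to compound 4 (1.51 log units; beyond the scatter). That last step is a bound, as compound 3 has only a limit: the limit of >= 396000 nM in this assay, at which 1 of the 4 values shown sits.

The compounds shown leave open whether the amino link or the ring it carries goes with the lower numbers. A pyridin-2-ylmethyl group on this carbon would separate the two.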